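The source may hold more compounds than are shown below. What is called first, only, known or untested is meant among the compounds shown, and "the series" means these compounds.

Measured in a functional assay on the whole organism (strain albino) for inhibition, with Rattus norvegicus as the target, read by paw edema, with stated times of 1 h and 2 h, at a dose of 100 mg/kg by the oral route; on this read-out higher numbers stand for more inhibition at the one dose given (going by the name of the read-out) and lower numbers for less inhibition:
compound 1, `O=C(CSc1nc(-c2ccc(Cl)cc2)c(C(=O)O)c(=O)[nH]1)Nn1c(COc2ccc(Cl)cc2Cl)nc2ccccc2c1=O`: 61.4%
compound 2, `O=C(CSc1nc(-c2ccc(O)cc2)c(C(=O)O)c(=O)[nH]1)Nn1c(COc2ccc(Cl)cc2Cl)nc2ccccc2c1=O`: 38.6%
compound 3, `Cn1c(SCC(=O)Nn2c(COc3ccc(Cl)cc3Cl)nc3ccccc3c2=O)nc(-c2ccc(Cl)cc2)c(C#N)c1=O`: 73.7%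

Compound 3 stands highest of the three numbers; its gaps to compound 1 and to compound 2 are both beyond the scatter. Within the data shown here, the one change measured twice on the same core is hydroxy in place of chloro on an aromatic carbon, which gave a number 22.8 percentage points lower from compound 1 to compound 2 (beyond the scatter). How the core of compound 3 differs from the core of compound 1 is not broken down here.

Compound 4, `Cn1c(SCC(=O)Nn2c(COc3ccc(Cl)cc3Cl)nc3ccccc3c2=O)nc(-c2ccc(O)cc2)c(C#N)c1=O`, is not yet measured. Against compound 3 it carries hydroxy in place of chloro on an aromatic carbon, the same kind of change, at a place described in the same words. Among the measured compounds shown here, a step of a number 21.7 percentage points lower from compound 3 to compound 4 (beyond the scatter) is expected in this assay, resting only on a single earlier step because a number 22.8 percentage points lower from compound 1 to compound 2 (beyond the scatter) is the one measured example, on a different core. Compound 4 is estimated at 52%, expected to fall between 38% and 66%.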

Compound 4, a percentage reported as inhibition, in the whole organism at one dose (the size of the read-out at that dose, not a potency): 86%
For compound 4 the middle estimate is 34 percentage points below the measured one, and the stated range ends below it.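

Replacing 4-chlorophenyl with 4-hydroxyphenyl gives a number 12.3 percentage points higher from compound 3 to compound 4 (beyond the scatter) in this assay. Set beside the earlier step, the change does not carry from one core to the other, in either direction or size: the same change on two cores in this assay, a number 22.8 percentage points lower (beyond the scatter) from compound 1 to compound 2 and a number 12.3 percentage points higher (beyond the scatter) from compound 3 to compound 4, 35.1 percentage points apart, beyond the scatter of two such steps. This shows that the outcome of the change depends on the core in these two pairs, but it does not show which difference between the cores is responsible, and two pairs give no rule for the wider series.

On these data alone, it remains open whether a methoxy group or an amine in the same place would follow compound 3 to compound 4 or compound 1 to compound 2. Separating the core differences would require pairs that differ in one place only.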